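The compounds below may be only part of what the source reports. "The series", "measured", "known", "first", "only" and "open" are said of these compounds alone.

Of the compounds shown here, two sharing one core have been measured in a functional assay on Jurkat cells (Homo sapiens) for antiproliferative activity, read by MTT assay; a lower number here means a stronger inhibitor, a higher number a weaker inhibitor. Compound 1 `COc1cc2c(cc1OC)C(=O)/C(=C/c1cc(F)cc(F)c1)C2` gives 19000 nM in this assay. Compound 2 `COc1cc2c(cc1OC)C(=O)/C(=C/c1cc(C)c(N)c(C)c1)C2` gives 55 nM in this assay, the lower of the two numbers, and its gap to compound 1 lies well beyond the usual scatter, so on these two numbers compound 2 stands as the stronger inhibitor. Compound 3 `COc1cc2c(cc1OC)C(=O)/C(=C/c1cc(C)c(OC(=O)OCC(C)C)c(C)c1)C2` has not yet been measured. It differs from compound 2 in one place: (isobutoxycarbonyl)oxy in place of amino on an aromatic carbon. Among the compounds with values here, no step between two measured compounds that differ in one place is available, so any expectation rests on the two values alone. Because compound 2 reaches 55 nM while compound 1 stays at 19000 nM, the group on this aromatic carbon is where the measured numbers move most, and replacing amino with (isobutoxycarbonyl)oxy is expected to cost potency. The step of a 9.1-fold higher number from compound 2 to compound 3 (0.96 log units; beyond the scatter) is therefore estimated to lie upward, beyond the scatter, yet well short of the distance to compound 1. Compound 3 is expected to give about 500 nM, within a range from 80 nM to 4000 nM.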

Compound 3, half-maximal inhibitory concentration: 21500 nM
Compound 3: middle estimate off by 43-fold (1.63 log units), on the low side; measured number above the stated range.
By their numbers in this assay, from the lowest: compound 2; then compounds 1 and 3 (each within the scatter of the next).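

In this assay, within the data shown here, putting (isobutoxycarbonyl)oxy in place of amino on the aromatic carbon ortho to two methyl groups gives a 390-fold higher number from compound 2 to compound 3 (2.59 log units; beyond the scatter), the first step between measured compounds that differ in one place. Compound 2 and compound 3 share the core and both methyl groups, so the two methyl groups alone do not secure the potency of compound 2, and the group on this one carbon decides much of it. The change replaces a group of 1 heavy atom that carries 1 hydrogen-bond donor with one of 8 heavy atoms that carries 0 hydrogen-bond donors, and nothing measured on these compounds explains the loss or singles out which of these differences matters.

The compounds shown leave open whether a small group on the same carbon, such as a hydroxyl or a methylamino group, or a larger one that keeps a nitrogen-hydrogen, such as an acetamide, would stay close to compound 2 or fall as far as compound 3. They also leave open what amino does on this carbon when one or both methyl groups are replaced by hydrogen.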